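Bromo substitution carried onto a weaker core

The compounds below may be only part of what the source reports. "The series", "measured", "known", "first", "only" and "open" are said of these compounds alone.

Measured compounds:
compound 1, `COc1ccc(C2CC(c3ccccc3)=NN2C2=NC(=O)/C(=C3\C(=O)Nc4ccccc43)S2)cc1`: 1640 nM
compound 2, `COc1ccc(C2CC(c3ccccc3)=NN2C2=NC(=O)/C(=C3\C(=O)Nc4ccc(Br)cc43)S2)cc1`: 250 nM
compound 3, `COc1ccc(C2=NN(C3=NC(=O)/C(=C4\C(=O)Nc5ccccc54)S3)C(c3ccc(Cl)cc3)C2)cc1`: 86600 nM

All three were tested in a functional assay on cells (Leukemia cell, Homo sapiens) for cytotoxicity, read by sulforhodamine B assay, with a stated time of 48 h; on this read-out lower numbers stand for stronger inhibition of growth and higher numbers for weaker inhibition of growth. Compound 2 differs from compound 1 only by bromo in place of hydrogen on an aromatic carbon, and this gave a 6.6-fold lower number from compound 1 to compound 2 (0.82 log units; beyond the scatter). Compound 3 carries a different core; how its core differs from that of compound 1 is not broken down here. In this assay compound 3 gives the highest number of the three, so it is the weakest of the measured compounds, well beyond the scatter of the other two.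

The unmeasured compound 4, `COc1ccc(C2=NN(C3=NC(=O)/C(=C4\C(=O)Nc5ccc(Br)cc54)S3)C(c3ccc(Cl)cc3)C2)cc1`, is built from compound 3 by bromo in place of hydrogen on an aromatic carbon. The place of this change is described in the same words as the change from compound 1 to compound 2, so the two are the same change made on two cores. Because the earlier step gave a 6.6-fold lower number from compound 1 to compound 2 (0.82 log units; beyond the scatter), the expectation is that the same change on the core of compound 3 lowers the number by a similar amount, and the step from compound 3 to compound 4 is estimated as a 6.7-fold lower number from compound 3 to compound 4 (0.82 log units; beyond the scatter). Going by these compounds, whether the bromo effect carries over between cores is untested beyond this single pair, so the range is kept wide. Compound 4 is therefore expected to give about 13000 nM in this assay, with a likely span from 4000 nM to 45000 nM.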

Compound 4, concentration for 50% growth inhibition: 190 nM
Compound 4: the middle estimate sits 68-fold (1.84 log units) above what was measured, outside the stated range (below it).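

In this assay, bromo in place of hydrogen on an aromatic carbon gives a 460-fold lower number from compound 3 to compound 4 (2.66 log units; beyond the scatter), so on this second core the change again lowers the number, and it does so by far more than on the first. Set side by side, the two steps point the same way but clearly differ in size, so the gain seen on one core could not be carried over as a fixed amount: the same change on two cores in this assay, a 6.6-fold lower number (0.82 log units; beyond the scatter) from compound 1 to compound 2 and a 460-fold lower number (2.66 log units; beyond the scatter) from compound 3 to compound 4, 69-fold (1.84 log units) apart, beyond the scatter of two such steps
Going by these compounds alone, this shows that the direction of the bromo step held on both cores while its size depended on the core it was made on, but with only two pairs it does not show why the sizes differ, nor that the direction would hold on any further core.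

The compounds shown leave open which part of the difference between the two cores goes with the much larger step, since those cores are not compared one change at a time. They also leave open whether another group on the same aromatic carbon, such as fluoro, methyl or nitro, would follow the bromo result, and whether its step would likewise change in size from one core to the other.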